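The source may hold more compounds than are shown below. What is called first, only, known or untested is meant among the compounds shown, and "the series" means these compounds.

Compound 3 (`C/C=C/C(=O)Nc1cccc(Oc2nc(Nc3ccc(OC)cc3)nc3c2CSCC3)c1`) gives 24300 nM in a functional assay on MCF7 cells (Homo sapiens) for antiproliferative activity, read by MTT assay, with a stated time of 72 h (on this read-out higher numbers stand for weaker inhibition and lower numbers for stronger inhibition), and lies within the scatter of compound 1 (`CCC/C=C/C(=O)Nc1cccc(Oc2nc(Nc3ccn(C)n3)nc3c2CSCC3)c1`) at 22600 nM in the same read-out. Compound 2 (`C=CC(=O)Nc1cccc(Oc2nc(Nc3ccc(OC)cc3)nc3c2CSCC3)c1`) gives a lower number of 11700 nM on this scale. The change to compound 4 (`CCC/C=C/C(=O)Nc1cccc(Oc2nc(Nc3ccc(OC)cc3)nc3c2CSCC3)c1`) is ethyl in place of hydrogen on a saturated chain carbon bound to a double-bonded chain carbon and turns prop-1-en-1-yl into pent-1-en-1-yl on the carbonyl. Among the measured compounds shown here, the only measured step on this group is a 2.1-fold higher number from compound 2 to compound 3 (0.32 log units; beyond the scatter) and it is modest, from vinyl to prop-1-en-1-yl. Compound 1 already carries pent-1-en-1-yl and shows 22600 nM with a different group elsewhere on the shared core, so it is only indirect evidence. With one small step and that single value, no clear shift is expected from the longer chain. The expected step in this assay is a 1.0-fold higher number from compound 3 to compound 4 (0.01 log units; within the scatter) and this stays within the scatter. In this assay compound 4 is estimated at 25000 nM with an expected range from 13000 nM to 48000 nM around that figure.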

Compound 4, half-maximal inhibitory concentration: > 50000 nM
Compound 4: no number, only a limit (the forecaster's own chance of this, stated with the estimate: 10%); middle value at least 2.0-fold (0.30 log units) away from the limit.
By their numbers in this assay, from the lowest: compounds 2, 1 and 3 (each within the scatter of the next, the first and the last beyond it). At a limit, above all of these: compound 4.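

Compound 4 stands at a limit of the assay, not at a number, in this assay: the limit of > 50000 nM in this assay, at which 1 of the 4 values shown sits. With 4-methoxyphenyl on the nitrogen, the earlier modest step on the carbonyl group, a 2.1-fold higher number from compound 2 to compound 3 (0.32 log units; beyond the scatter), now continues in the same direction, with an at least 2.0-fold higher number from compound 3 to compound 4 (0.31 log units; beyond the scatter) and, over the whole change from vinyl to pent-1-en-1-yl, an at least 4.2-fold higher number from compound 2 to compound 4 (0.63 log units; beyond the scatter). With pent-1-en-1-yl in place, the group on the nitrogen also matters, with 4-methoxyphenyl replacing 1-methyl-1H-pyrazol-3-yl giving an at least 2.2-fold higher number from compound 1 to compound 4 (0.34 log units; beyond the scatter).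

The compounds shown leave open whether an amine on the chain, a carboxylic acid or a branched chain on the carbonyl would follow the same direction as pent-1-en-1-yl. They also leave open how 1-methyl-1H-pyrazol-3-yl on the nitrogen behaves with vinyl on the carbonyl.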